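The source may report more compounds than this note shows. Statements on the series, on what has been measured and on what is new or still open speak of the compounds shown alone.

Notes on the series. Compound 1 `CN(C)c1ccc(Nc2nc(-c3ccncc3)nc3c2CC(N)CC3)cc1` gives 11500 nM in a functional assay on DU-145 cells (Homo sapiens) for antiproliferative activity, read by MTT assay, with a stated time of 72 h; a lower number here means a stronger inhibitor, a higher number a weaker inhibitor. Compound 2 `N[C@@H]1CCc2nc(-c3ccncc3)nc(Nc3cccc(F)c3)c2C1` gives 11100 nM and compound 3 `COc1cccc(Nc2nc(-c3ccncc3)nc3c2CC(N)CC3)c1` gives 8800 nM in this assay. Compound 1 stands highest of the three numbers; compound 2 is nearest and compound 3 furthest, yet neither gap exceeds the scatter, so no ranking of the three can be drawn from these numbers. Going by the values given here, the only single-site step among the measured compounds is a 1.3-fold lower number from compound 1 to compound 3 (0.12 log units; within the scatter), an exchange at the same nitrogen on an aromatic ring as the one considered below.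

Compound 4 `NC1CCc2nc(-c3ccncc3)nc(Nc3cccc(F)c3)c2C1` differs from compound 1 as follows: 3-fluorophenyl in place of 4-(dimethylamino)phenyl on a nitrogen on an aromatic ring. Two observations bear on this. The step from compound 1 to compound 3, which swaps the group at the same place, stayed within the scatter. Compound 2 has the same constitution as compound 4, with the amine stereocentre specified, and compound 2 gives a number within the scatter of compound 1. Neither observation points to a shift beyond the scatter in this assay. Compound 4 is therefore expected to give 11000 nM, with a range of 5500 nM to 22000 nM. The expected step in this assay is a 1.0-fold lower number from compound 1 to compound 4 (0.02 log units; within the scatter), within the scatter.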

Compound 4, half-maximal inhibitory concentration in the DU-145 assay: 15100 nM
Estimate against measurement, compound 4: 1.4-fold (0.14 log units) below, and the stated range covers the measured number.
By their numbers in the DU-145 assay, from the lowest: compounds 3, 2, 1 and 4 (each within the scatter of the next).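

At this place on the nitrogen, the DU-145 assay now gives a direct reading of 3-fluorophenyl against both earlier groups: a 1.3-fold higher number from compound 1 to compound 4 (0.12 log units; within the scatter), and a 1.7-fold higher number from compound 3 to compound 4 (0.23 log units; within the scatter), so three different aryl groups at this nitrogen (4-(dimethylamino)phenyl, 3-methoxyphenyl and 3-fluorophenyl) stay within the scatter of one another, and drawing the amine stereocentre brings no readable change either, with a 1.4-fold higher number from compound 2 to compound 4 (0.13 log units; within the scatter), the only difference being this: the fact that one of compounds 2 and 4 is drawn with a defined configuration and the other without, at the place where they differ
In a physicochemical assay for solubility, read by HPLC, in phosphate buffer, measured as kinetic solubility, with a stated time of 24 h, at pH 7.4 (on this read-out lower numbers stand for lower solubility and higher numbers for higher solubility), compound 1 gives > 250000 nM, which is a limit of the assay and not a number.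
In the physicochemical assay compound 4 gives 126000 nM, and the step between compound 1 and compound 4 in this read-out cannot be read.

The compounds shown leave open whether any group at this nitrogen moves the antiproliferative number beyond the scatter, for example a phenyl carrying a carboxylic acid or a primary amine, or a longer alkyl chain in place of the aryl ring. Also open, from the compounds shown here alone, is how the configuration opposite to the R drawn in compound 2 reads in the DU-145 assay.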